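A few compounds are considered here, and "the series" means these few. Any claim that something is new, unique, unknown or untested is made for them only; others in the source may bear on it.

Working notes on the series.

Compound 1 `CCN(CC)Cc1ccc(NC(=O)NN=C(c2ccccn2)c2ccccn2)cc1` carries a diethylamino group on a saturated chain carbon bound to an aromatic carbon. In a functional assay on MCF7 cells (Homo sapiens) for antiproliferative activity, read by CCK-8 assay, with a stated time of 24 h (a higher number here means a weaker inhibitor, a lower number a stronger inhibitor), compound 1 gives only a limit, > 40000 nM. Compound 2 `CC1CCN(Cc2ccc(NC(=O)NN=C(c3ccccn3)c3ccccn3)cc2)CC1` shares the core of compound 1 and differs by the change (4-methylpiperidin-1-yl in place of diethylamino on a saturated chain carbon bound to an aromatic carbon). In this assay compound 2 likewise gives only a limit, > 40000 nM. The step that the two limits leave unreadable from compound 1 to compound 2 therefore cannot be read as a size, because the limit of > 40000 nM in this assay, at which 2 of the 3 values shown sit, holds for both ends of it.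

Compound 3 `CCN(CC)Cc1ccc(NC(=O)NN=C(c2ccccc2)c2ccccc2)cc1` has a different core; how the core of compound 3 and the core of compound 1 differ is not broken down here. In this assay, within the data shown here, compound 3 gives 13100 nM, the only finite number in the set so far.

Compound 4 `CC1CCN(Cc2ccc(NC(=O)NN=C(c3ccccc3)c3ccccc3)cc2)CC1` carries the core of compound 3 and differs from it by 4-methylpiperidin-1-yl in place of diethylamino on a saturated chain carbon bound to an aromatic carbon, the same change as from compound 1 to compound 2. Since the earlier step of this kind sits entirely at the limit, its size gives no guide. The expectation for compound 4 rests on the finite value of compound 3, 13100 nM, with no measured reason to move far from it. The step from compound 3 to compound 4 is expected to be roughly flat, a 1.1-fold higher number from compound 3 to compound 4 (0.06 log units; within the scatter). Compound 4 is accordingly estimated at 15000 nM, with a range from 6000 nM to 40000 nM, and a real chance that only a limit is returned.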

Compound 4, half-maximal inhibitory concentration: 13300 nM
Estimate against measurement, compound 4: 1.1-fold (0.05 log units) above, and the stated range covers the measured number.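

In this assay, 4-methylpiperidin-1-yl in place of diethylamino on a saturated chain carbon bound to an aromatic carbon gives a 1.0-fold higher number from compound 3 to compound 4 (0.01 log units; within the scatter) on the core of compound 3, so on this core the exchange of an open group of 5 heavy atoms for a ring-bearing group of 7 heavy atoms leaves the two values within the scatter of each other. The same change on the core of compound 1, from compound 1 to compound 2, cannot be read as a size, because both of its ends sit at a limit: the limit of > 40000 nM in this assay, at which 2 of the 4 values shown sit. The series therefore offers a single readable step for this change, which does not show whether the two cores respond alike and sets no pattern that can be carried from one core to the other.

Left open is whether a morpholine ring or a dimethylamino group on the same saturated chain carbon would give a step beyond the scatter on the core of compound 3. Also open, going by these compounds, is whether any amine in that place on the core of compound 1 would give a finite number, which a direct comparison of the change on both cores would need.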